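Lengthening the Amine Side Chain: From Compound 2 to Compound 3

The compounds below may be only part of what the source reports. "The series", "measured", "known", "first", "only" and "open" are said of these compounds alone.

- compound 1 `CCN(CC)CCCOc1c(-c2cc(OC)c(OC)c(OC)c2)oc2ccccc2c1=O` with 37600 nM
- compound 2 `CCCCN(CCCC)CCCCCOc1c(-c2cc(OC)c(OC)c(OC)c2)oc2ccccc2c1=O` with 7800 nM

In a functional assay on LNCaP cells (Homo sapiens) for antiproliferative activity, read by WST assay, with a stated time of 3 days (a higher number here means a weaker inhibitor, a lower number a stronger inhibitor), compound 2 holds the lower of the two numbers. Compound 3 `CCCCCN(CCCCC)CCCCOc1c(-c2cc(OC)c(OC)c(OC)c2)oc2ccccc2c1=O` differs from compound 2 by dipentylamino in place of (dibutylamino)methyl on a saturated chain carbon, four bonds along the chain from an oxygen on an aromatic ring, with dipentylamino in place of (dibutylamino)methyl. For the measured compounds named here, only one measured step bears on this: a 4.8-fold lower number from compound 1 to compound 2 (0.68 log units; beyond the scatter). That swap was larger than this one, so only a small move toward lower numbers is expected in this assay, perhaps none beyond the scatter. The expected step is a 1.3-fold lower number from compound 2 to compound 3 (0.11 log units; within the scatter) for this change. The estimate for compound 3 is 6000 nM, within an expected range of 2500 nM to 14000 nM, and the measurement remains to be made.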

Compound 3, half-maximal inhibitory concentration: 9700 nM
The estimate for compound 3 lay 1.6-fold (0.21 log units) below the measured number, and the stated range covers the measured number.
By their numbers in this assay, from the lowest: compounds 2 and 3 (each within the scatter of the next); then compound 1.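

In this assay, dipentylamino in place of (dibutylamino)methyl gives a 1.2-fold higher number from compound 2 to compound 3 (0.09 log units; within the scatter), so this swap on the saturated chain carbon moves the number no further than the scatter. Compound 3 still keeps a clear edge over the diethylamino compound, with a 3.9-fold lower number from compound 1 to compound 3 (0.59 log units; beyond the scatter), showing that a second large dialkylamino end also stays beyond the scatter. Nothing measured here explains these numbers. The compounds shown leave open whether an amine held in a ring, such as piperidine or morpholine, would match these open-chain amines, and how a carboxylic acid at the chain end would fare.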